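The source may report more compounds than this note shows. Statements on the series, on what has been measured and on what is new or still open speak of the compounds shown alone.

Measured so far in a functional assay on CHO cells for antagonist activity at Orexin receptor type 2 (Homo sapiens), read by FLIPR and calcium flux; on this read-out higher numbers stand for weaker inhibition and lower numbers for stronger inhibition:
- compound 1 `COc1ccc(C)cc1NC(=O)CSc1nnc(-c2ccoc2C)n1Cc1ccco1`: 15.9 nM
- compound 2 `Cc1occc1-c1nnc(SCC(=O)Nc2cccc(F)c2)n1Cc1ccco1`: 501 nM

Compound 2 holds the highest number of the two in this assay; its nearest neighbour, compound 1, lies a long way lower, the gap being a 32-fold higher number from compound 1 to compound 2 (1.50 log units; beyond the scatter). That step came from swapping the aryl group on the amide-type nitrogen, 3-fluorophenyl in place of 2-methoxy-5-methylphenyl, and it was large.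

Compound 3 `Cc1occc1-c1nnc(SCC(=O)Nc2ccc(Cl)cc2)n1Cc1ccco1` is the next member. It differs from compound 2 by 4-chlorophenyl in place of 3-fluorophenyl on an amide-type nitrogen. Among the compounds with values here, the only step in hand that touches this spot is the one from compound 1 to compound 2, and it shows that exchanging the aryl group on that nitrogen can move the number a great deal. Within the data shown here, no measured pair, however, compares two halogenated phenyl groups, so the direction of the present change cannot be read from what exists. The working expectation is a moderate change at most, leaning toward a somewhat lower number, with wide uncertainty: the step from compound 2 to compound 3 is estimated as a 1.4-fold lower number from compound 2 to compound 3 (0.16 log units; within the scatter). For compound 3 the estimated value in this assay is 350 nM, between 80 nM and 1600 nM.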

Compound 3, inhibition constant: 100 nM
Compound 3: middle estimate off by 3.5-fold (0.54 log units), on the high side; low and high end bracket the measured number.
By their numbers in this assay, from the lowest: compound 1; then compound 3; then compound 2.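

In this assay, the aryl group on the amide-type nitrogen distinguishes even between two halogenated phenyl groups: 4-chlorophenyl in place of 3-fluorophenyl gives a 5.0-fold lower number from compound 2 to compound 3 (0.70 log units; beyond the scatter), so sensitivity at this position is not confined to the exchange involving 2-methoxy-5-methylphenyl. That group still gives the lower number, with a 6.3-fold higher number from compound 1 to compound 3 (0.80 log units; beyond the scatter), so 4-chlorophenyl closes only part of the gap left by 3-fluorophenyl. No supporting data are available to explain the difference between the two halogenated groups.

The step from compound 2 to compound 3 changes the halogen and its place on the phenyl ring together, leaving their contributions unseparated; a 4-fluorophenyl group on the same nitrogen would isolate the halogen exchange from the 3-fluorophenyl side. Going by these compounds, the separate contributions of the methoxy and methyl groups in compound 1 also remain open, as does whether the order of these three aryl groups would hold with a different group on the shared core.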